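The source may report more compounds than this note shows. Statements on the series, on what has been measured and on what is new or still open speak of the compounds shown alone.

In a functional assay with Oryctolagus cuniculus as the target (on this read-out higher numbers stand for weaker inhibition and lower numbers for stronger inhibition), three compounds built on the shared core have been read, and none of the readings is an exact number. Compound 1, `COc1ccc(-c2nc(/N=C(\N)N3CCOCC3)sc2-c2ccc(OC)cc2)cc1`, gives < 1000 nM, which is a limit. Compound 2, `COc1ccc(-c2nc(CNC(=O)CSC)sc2-c2ccc(OC)cc2)cc1`, gives < 100 nM, also a limit. Going by these compounds, compound 3, `COc1ccc(-c2nc(C(N)=O)sc2-c2ccc(OC)cc2)cc1`, gives > 1000 nM, again a limit, so its exact standing remains open.

Compound 4, `CCOC(=O)/C=C/c1nc(-c2ccc(OC)cc2)c(-c2ccc(OC)cc2)s1`, awaits measurement. The difference is 2-(ethoxycarbonyl)ethenyl in place of carbamoyl on an aromatic carbon: 2-(ethoxycarbonyl)ethenyl in place of carbamoyl, on the aromatic carbon that carries the variable group in all of these compounds.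

Among the measured compounds shown here, three measured steps bear on this change, and all of them concern that same carbon. The only one with a readable lower bound is an at least 10-fold higher number from compound 2 to compound 3 (1.00 log units; beyond the scatter). The step of a number no lower from compound 1 to compound 3 (the limit leaves the size open) leaves its size open, and a step that the two limits leave unreadable from compound 1 to compound 2 cannot be sized at all. Neither compound 1 nor compound 2 carries the entering group, so these steps offer only a loose guide. In this assay, a lower number and thus stronger inhibition is expected on leaving carbamoyl, by a modest or larger margin, given an at least 10-fold higher number from compound 2 to compound 3 (1.00 log units; beyond the scatter). The step expected here is an at least 3.3-fold lower number from compound 3 to compound 4 (0.52 log units; beyond the scatter). Compound 4 is estimated at 300 nM, with an expected range from 50 nM to 2000 nM.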

Compound 4, half-maximal inhibitory concentration: 20 nM
The estimate for compound 4 lay 15-fold (1.18 log units) above the measured number; measured number below the stated range.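

In this assay, 2-(ethoxycarbonyl)ethenyl in place of carbamoyl gives an at least 50-fold lower number from compound 3 to compound 4 (1.69 log units; beyond the scatter), the first large step shown on this aromatic carbon and the first that leads away from carbamoyl to a lower number. Among the compounds shown here, compound 4 gives 20 nM, the first exact number, and its group, with 0 hydrogen-bond donors, shows that strong inhibition at this carbon does not depend on a donor in the substituent. The reading for compound 3 is a limit, so the step marks only the smallest size it can have: the limit of > 1000 nM in this assay, at which 1 of the 4 values shown sits.

The steps to compound 4 from compound 1 and from compound 2 cannot be read, so the order among these three compounds stays open. Also open, going by these compounds, is which part of the entering group matters, as the ethenyl link and the ethyl ester change together here, and a carboxylic acid or a primary amide on the same two-carbon chain, or a saturated chain carrying the ethyl ester, would be needed to separate them.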